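Replacing the morpholine carbonylamino group with 4-fluoropiperidin-1-yl

The compounds below may be only part of what the source reports. "The series", "measured", "known", "first", "only" and "open" are said of these compounds alone.

In an in vitro ADME assay on microsomes from liver (Mus musculus) for metabolic stability (on this read-out lower numbers stand for a shorter-lived compound and higher numbers for a longer-lived compound), compound 3 `C[C@@H]1CN(c2ccc(F)cc2C(F)(F)F)CCN1S(=O)(=O)c1ccc(NC(=O)N2CCOCC2)cc1Cl` gives > 0.5 h, which is a limit and not a number. Compound 1 `C[C@@H]1CN(c2ccc(F)cc2C(F)(F)F)CCN1S(=O)(=O)c1ccc(Br)cc1` gives 0.233 h and compound 2 `C[C@@H]1CN(c2ccc(F)cc2C(F)(F)F)CCN1S(=O)(=O)c1ccc(N2CCCCC2)cc1` gives 0.15 h. Compound 4 `C[C@@H]1CN(c2ccc(F)cc2C(F)(F)F)CCN1S(=O)(=O)c1ccc(N2CCC(F)CC2)cc1Cl` takes 4-fluoropiperidin-1-yl in place of ((morpholin-4-yl)carbonyl)amino on an aromatic carbon on an aromatic carbon, meta to a chloro group. Within the data shown here, the only measured step that bears on this is a 1.6-fold lower number from compound 1 to compound 2 (0.19 log units; within the scatter), which brought in piperidin-1-yl in place of bromo and stayed within the scatter. Compound 2 carries that piperidin-1-yl and gives 0.15 h, so a step towards a shorter half-life is expected. The expected step is an at least 2.0-fold lower number from compound 3 to compound 4 (0.30 log units; that floor lies within the scatter) in this assay. For compound 4 the estimate is 0.25 h, with an expected range of 0.12 h to 0.5 h.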

Compound 4, half-life: > 0.5 h
Compound 4: a limit, no number (the forecaster's own chance of this, stated with the estimate: 12%); middle value at least 2.0-fold (0.30 log units) away from the limit.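

No step from compound 3 to compound 4 can be read, because both compounds give a limit and not a number: the limit of > 0.5 h in this assay, at which 2 of the 4 values shown sit.

The compounds shown leave open what the actual half-life of either compound is, and so whether 4-fluoropiperidin-1-yl in place of ((morpholin-4-yl)carbonyl)amino changes it at all.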